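Swapping the Triazole Substituent in an Inactive Pair

The source may report more compounds than this note shows. Statements on the series, on what has been measured and on what is new or still open speak of the compounds shown alone.

The study measures a functional assay on A549 cells (Homo sapiens) for inhibition, read by MTT assay, with a stated time of 24 h; a lower number here means a stronger inhibitor, a higher number a weaker inhibitor. Compound 1, `CCOC(=O)C1=Cc2ccccc2OC1(OCc1cn(CC(=O)Nc2ccccc2Br)nn1)C(F)(F)F`, reaches only the limit of that measurement: in this assay compound 1 gives > 150000 nM, which is a limit rather than a number. Compound 2, `O=C(O)C1=Cc2ccccc2OC1(OCc1cc(-c2ccc([N+](=O)[O-])cc2)no1)C(F)(F)F`, stops at the same point; in this assay compound 2 gives > 150000 nM, again a limit and not a number. Compound 1 therefore stands where every value shown stands, at the limit of > 150000 nM in this assay, at which 2 of the 2 values shown sit.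

Compound 3, `CCOC(=O)C1=Cc2ccccc2OC1(OCc1cn(-c2cccc(C(F)(F)F)c2)nn1)C(F)(F)F`, has not yet been measured in this assay. It differs from compound 1 in one place: 3-(trifluoromethyl)phenyl in place of ((2-bromophenyl)carbamoyl)methyl on an aromatic nitrogen. Within the data shown here, no step between two measured compounds is known, so the size of this change cannot be read from any measured pair. Since both measured compounds sit at the limit, the change is expected to produce no step beyond the scatter. The expected step is estimated as a number no higher from compound 1 to compound 3 (the limit leaves the size open). Compound 3 is expected to give 150000 nM, with a range from 60000 nM to 400000 nM, and most likely the assay will again report only a limit.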

Compound 3, half-maximal inhibitory concentration: > 150000 nM
Compound 3 ended at the assay's limit; the forecaster's own chance of this, stated with the estimate: 75%; the middle value lies on the limit itself.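

Compound 1 and compound 3 both end at a limit in this assay, so no step from one to the other can be read: the limit of > 150000 nM in this assay, at which 3 of the 3 values shown sit.

The compounds shown leave open how strongly any of them inhibits in this assay, and whether any change to the shared core or its side groups would give a number rather than a limit.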